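Methyl for methoxy: carrying one small step to compound 4

The source may report more compounds than this note shows. Statements on the series, on what has been measured and on what is new or still open speak of the compounds shown alone.

Measured so far in a functional assay on Hs 683 cells (Homo sapiens) for cytotoxicity, read by MTT assay, with a stated time of 72 h; on this read-out lower numbers stand for stronger inhibition and higher numbers for weaker inhibition:
compound 1 `COc1ccc2[nH]c(-c3ccc[nH]3)c(C3CC(=O)NC3=O)c2c1` gives 6000 nM
compound 2 `COc1ccc2[nH]c(-n3cccn3)cc2c1` gives 69000 nM
compound 3 `Cc1ccc2[nH]c(-c3ccc[nH]3)c(C3CC(=O)NC3=O)c2c1` gives 8000 nM

Compound 1 and compound 3 share one core and differ in a single place: methyl in place of methoxy on an aromatic carbon. The step is a 1.3-fold higher number from compound 1 to compound 3 (0.12 log units; within the scatter). Compound 2 carries a different core; the difference between the two cores is not broken down here. In this assay compound 2 gives the highest of the three numbers, beyond the scatter from both compound 1 and compound 3.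

Compound 4 `Cc1ccc2[nH]c(-n3cccn3)cc2c1` is not yet measured. It differs from compound 2 by the same change, at a place described in the same words: methyl in place of methoxy on an aromatic carbon. Because a 1.3-fold higher number from compound 1 to compound 3 (0.12 log units; within the scatter) lies within the scatter, the expected step is a 1.2-fold higher number from compound 2 to compound 4 (0.06 log units; within the scatter), also within the scatter. Compound 4 is therefore estimated at 80000 nM, between 40000 nM and 160000 nM. This rests on a single measured pair on a different core.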

Compound 4, half-maximal inhibitory concentration: > 100000 nM
Compound 4: only a limit was reported; the forecaster's own chance of this, stated with the estimate: 10%; middle value at least 1.2-fold (0.09 log units) from the limit.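

In this assay compound 4 gives > 100000 nM, a limit of the assay and not a number. On the core of compound 2, methyl in place of methoxy gives an at least 1.4-fold higher number from compound 2 to compound 4 (0.16 log units; that floor lies within the scatter). Carrying the change to this second core shows no sign of a lower number, but the size of the step remains unknown, so equal steps on the two cores are neither shown nor excluded: the same change on two cores in this assay, a 1.3-fold higher number (0.12 log units; within the scatter) from compound 1 to compound 3 and an at least 1.4-fold higher number (0.16 log units; that floor lies within the scatter) from compound 2 to compound 4; the limit leaves it open whether they differ

The compounds shown leave open how an amine or a carboxylic acid on this aromatic carbon would read on either core. They also leave open whether a longer chain, such as ethoxy, would follow methoxy or methyl.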